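A few compounds are considered here, and "the series" means these few. Any claim that something is new, unique, unknown or untested is made for them only; others in the source may bear on it.

Working notes on the series. Compound 1 `COc1ccc(-n2nc(C(=O)Nc3ccccc3OC)nc2-c2cc(OC)c(OC)c(OC)c2)cc1`, the lowest of the two numbers measured in a functional assay on the whole organism for inhibition, with Rattus norvegicus as the target, read by paw edema, with stated times of 30 min and 3 h, at a dose of 0.28 mmol/kg by the oral route (on this read-out higher numbers stand for more inhibition at the one dose given (going by the name of the read-out) and lower numbers for less inhibition), gives 38%. Its nearest neighbour is compound 2 `COc1ccc(-n2nc(C(=O)Nc3cccc(F)c3)nc2-c2cc(OC)c(OC)c(OC)c2)cc1`, and in this assay compound 2 gives 92%; the step of a number 54 percentage points higher from compound 1 to compound 2 (beyond the scatter) shows that replacing the group on the amide-type nitrogen can move the read-out a long way. Compound 3 `COc1ccc(-n2nc(C(=O)Nc3ccc(C(=O)O)cc3)nc2-c2cc(OC)c(OC)c(OC)c2)cc1` differs from compound 1 in one place: 4-carboxyphenyl in place of 2-methoxyphenyl on an amide-type nitrogen. Among the measured compounds shown here, the only measured step bearing on this is the one from compound 1 to compound 2, and it was large, but the group entering there is not the one entering here, so it fixes the size of the effect only loosely. Since compound 1 sits at the bottom of the two numbers, a rise is expected, estimated as a number 22 percentage points higher from compound 1 to compound 3 (beyond the scatter). Compound 3 is therefore expected to reach about 60% in this assay, within a range of 30% to 85%.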

Compound 3, a percentage reported as inhibition, in the whole organism at one dose (the size of the read-out at that dose, not a potency): 95%
Beside the measured number, compound 3's estimate is 35 percentage points below it; the whole stated range lies below it.
By their numbers in this assay, from the lowest: compound 1; then compounds 2 and 3 (each within the scatter of the next).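

In this assay the 4-carboxyphenyl group gives a number 57 percentage points higher from compound 1 to compound 3 (beyond the scatter) and so joins the 3-fluorophenyl group: the large rise on the amide-type nitrogen is not tied to a single group replacing 2-methoxyphenyl. The read-out gives a number 3 percentage points higher from compound 2 to compound 3 (within the scatter) and does not separate these two entering groups, although only 4-carboxyphenyl brings a hydrogen-bond donor. No measurement at hand accounts for either rise or for the match between the two groups.

Open, as far as these compounds go, is how an unsubstituted phenyl group, a 4-aminophenyl group or a carboxylic acid on a longer chain would read on this nitrogen. Such groups would help show whether 2-methoxyphenyl pulls the number down or the other two groups lift it.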